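The source may hold more compounds than are shown below. What is called first, only, known or untested is meant among the compounds shown, and "the series" means these compounds.

Measured compounds:
compound 1, `COC1=CC(=O)C=C(Br)C1=O`, in an assay on isolated protein for inhibition of Polyunsaturated fatty acid 5-lipoxygenase (Homo sapiens), read by ELISA, with a stated time of 10 min (on this read-out lower numbers stand for stronger inhibition and higher numbers for weaker inhibition), compound 1 gives 1670 nM
compound 2, `CCCCCCCCCCCCCCCc1cc(O)cc(OC)c1O`, in this assay compound 2 gives 140 nM
compound 3, `CCCCCCCCCCCCCCCC1=CC(=O)C=C(OC)C1=O`, in this assay compound 3 gives 790 nM

Compound 1 stands at the highest of the three numbers. Its nearest neighbour is compound 3, whose number is lower by more than the usual scatter; compound 2 lies much further below it. Among the compounds with values here, no two of the measured compounds differ in a single place, so no step between measured compounds can be read directly.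

Compound 4, `CCCCCC1=CC(=O)C=C(OC)C1=O`, is not yet measured. It differs from compound 1 as follows: pentyl in place of bromo on a double-bonded ring carbon. Compound 3 carries a long chain at the same kind of position on the same core and sits below compound 1, which is the only pointer the set offers for a chain in place of bromo. The pentyl chain is far shorter than that of compound 3, so only a modest step downward in this assay is expected, likely close to the edge of the scatter.

For compound 4 the expected value is 1100 nM, within 450 nM to 2600 nM, which means an expected step of a 1.5-fold lower number from compound 1 to compound 4 (0.18 log units; within the scatter).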

Compound 4, half-maximal inhibitory concentration: 1370 nM
For compound 4 the middle estimate is 1.2-fold (0.10 log units) below the measured one, and the stated range covers the measured number.
By their numbers in this assay, from the lowest: compound 2; then compounds 3, 4 and 1 (each within the scatter of the next, the first and the last beyond it).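

In this assay, within the data shown here, pentyl in place of bromo on a double-bonded ring carbon gives a 1.2-fold lower number from compound 1 to compound 4 (0.09 log units; within the scatter), the first step that can be read at a single place. At this position, the assay does not separate bromo from pentyl, even though the entering group is a carbon chain and the leaving group a single bromine atom. No measurement on these compounds offers an explanation for this step.

From the compounds shown here alone, how a decyl chain, an amine or a carboxylic acid on this ring carbon would read in this assay remains open. Also open, going by these compounds, is whether the methoxy group on the shared core can be exchanged for an ethoxy group or a hydroxyl group with as little effect on the number.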